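This account rests on a few compounds, and the source may have more. Where it says the series, first, only, none or still open, it means among the compounds named here.

In a functional assay on MDA-MB-231 cells (Homo sapiens) for antiproliferative activity, read by MTT assay, with a stated time of 72 h (a lower number here means a stronger inhibitor, a higher number a weaker inhibitor), compound 1 `CC(=O)O[C@H]1CC[C@]2(C)[C@H](CC[C@@](C)(O)[C@H]2CC[C@@H]2C(C)=CC[C@H]3[C@H](CC[C@]3(C)O)C2(C)C)OC1(C)C` gives 38000 nM, and compound 2 `CC(=O)O[C@H]1CC[C@]2(C)[C@H](CC[C@@](C)(O)[C@H]2CC[C@@H]2C(C)=CC[C@H]3[C@H](CC[C@]3(C)OC(C)=O)C2(C)C)OC1(C)C` gives 26200 nM. Within the data shown here, these are the only two measured values, and they lie within the scatter of each other, so compound 1 has no clear rank. Compound 3 `CC1=CC[C@H]2[C@H](CC[C@]2(C)O)C(C)(C)[C@@H]1CC[C@H]1[C@]2(C)CC[C@H](OC(=O)CCC(=O)O)C(C)(C)O[C@H]2CC[C@@]1(C)O` differs from compound 1 by carboxymethyl in place of hydrogen on a saturated chain carbon bound to a carbonyl carbon. The same difference reads acetoxy to ((2-carboxyethyl)carbonyl)oxy. Among the measured compounds shown here, the one measured step, a 1.5-fold lower number from compound 1 to compound 2 (0.16 log units; within the scatter), places acetyl on a different oxygen and leaves the acetoxy of compound 1 unchanged. It therefore bears on the new change only loosely, and no measurement tests a change at the acetoxy itself. For the measured compounds named here, with that small step as the only guide, no shift beyond the scatter is expected in this assay, though the uncertainty is wide. The estimated step is a 1.4-fold lower number from compound 1 to compound 3 (0.13 log units; within the scatter). The expected value for compound 3 is 28000 nM, within an estimated range of 12000 nM to 65000 nM.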

Compound 3, half-maximal inhibitory concentration: 27900 nM
The estimate for compound 3 lay 1.0-fold (0.00 log units) above the measured number; the range from low to high includes it.
By their numbers in this assay, from the lowest: compounds 2, 3 and 1 (each within the scatter of the next).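

In this assay, the acetoxy of compound 1 is now tested directly: carboxymethyl in place of hydrogen on the saturated chain carbon bound to a carbonyl carbon gives a 1.4-fold lower number from compound 1 to compound 3 (0.13 log units; within the scatter). Among these compounds, the earlier step changed a different oxygen, so this is the first sign that this place can carry ((2-carboxyethyl)carbonyl)oxy, with its four added heavy atoms and one hydrogen-bond donor, without a step beyond the scatter. No evidence is available to account for this result.

All three compounds lie within the scatter of their neighbours, so none shows whether any change at this place can move the number beyond it. An amine at the end of the chain, a longer chain carrying the carboxylic acid, or a plain hydroxy in place of the acetoxy remains an open question.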